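Dropping the ortho methyl: from compound 2 to compound 4

This account rests on a few compounds, and the source may have more. Where it says the series, first, only, none or still open, it means among the compounds named here.

Measured compounds and their values in an assay on isolated protein for agonist activity at Free fatty acid receptor 1 (Homo sapiens); on this read-out higher numbers stand for an effect only at larger amounts of compound and lower numbers for an effect already at smaller amounts:
- compound 1, `CC#CC(CC(=O)O)c1ccc(OCc2ccc3nc(-c4ccc(F)cc4F)cn3c2)cc1`, gives 825 nM
- compound 2, `CC#CC(CC(=O)O)c1ccc(OCc2ccc3nc(-c4ccccc4C)cn3c2)cc1`, gives 389 nM
- compound 3, `CC#CC(CC(=O)O)c1ccc(OCc2ccn3cc(-c4cccc(C)c4)nc3c2)cc1`, gives 1510 nM

Compound 2 has the lowest of the three numbers, so it is the most potent of the set. Its closest neighbour is compound 1, which sits a step away: a 2.1-fold lower number from compound 1 to compound 2 (0.33 log units; beyond the scatter). Compound 3, built on a differently arranged core and carrying its methyl at a different place on the outer ring, gives a clearly higher number than compound 2.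

The unmeasured compound 4, `CC#CC(CC(=O)O)c1ccc(OCc2ccc3nc(-c4ccccc4)cn3c2)cc1`, keeps everything of compound 2 except one detail: hydrogen in place of methyl on an aromatic carbon. Among the compounds with values here, only one measured step touches that outer ring, the change from compound 1 to compound 2, and it was modest. Within the data shown here, removing the methyl altogether has no direct precedent here, so the methyl's contribution is uncertain; a small loss is the more likely outcome, but a change within the scatter is possible. The expected step is therefore a 1.6-fold higher number from compound 2 to compound 4 (0.20 log units; within the scatter). Compound 4 is estimated at 620 nM, with a range from 300 nM to 1300 nM.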

Compound 4, half-maximal effective concentration: 979 nM
Beside the measured number, compound 4's estimate is 1.6-fold (0.20 log units) below it; low and high end bracket the measured number.
By their numbers in this assay, from the lowest: compound 2; then compounds 1, 4 and 3 (each within the scatter of the next).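

In this assay, 2-methylphenyl to phenyl gives a 2.5-fold higher number from compound 2 to compound 4 (0.40 log units; beyond the scatter) and so isolates the methyl ortho to a large group, showing that this single carbon makes a difference that can be read on its own. Phenyl in place of 2,4-difluorophenyl gives a 1.2-fold higher number from compound 1 to compound 4 (0.07 log units; within the scatter) and so leaves the two rings indistinguishable, which means that among these three compounds only the 2-methylphenyl ring stands apart, and substitution on the outer ring does not in itself separate a compound from the plain phenyl. No measurement available here explains what the methyl does at this position.

On these data alone, whether an ethyl group, a methoxy group or a single chlorine atom in the methyl's place would match it remains open. So does whether a lone fluorine atom there would behave like the methyl.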